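The source may hold more compounds than are shown below. What is called first, only, known or untested is meant among the compounds shown, and "the series" means these compounds.

Working notes on the series in a functional assay on SW-620 cells (Homo sapiens) for inhibition, read by MTT assay, with a stated time of 48 h; a lower number here means a stronger inhibitor, a higher number a weaker inhibitor.

Compound 1 `Cc1ccc(NC(=S)NC(=O)c2ccc(OCc3cccc(Cl)c3Cl)cc2)cc1-c1nc2ccccc2[nH]1` is recorded only as a limit of the assay, > 100000 nM. Compound 2 `Cc1ccc(NC(=O)NC(=O)c2ccc(OCc3cccc(C(F)(F)F)c3)cc2)cc1-c1nc2ccccc2[nH]1` gives 9640 nM. Compound 3 `Cc1ccc(NC(=O)NC(=O)c2ccc(OCc3ccccc3F)cc2)cc1-c1nc2ccccc2[nH]1` gives 4110 nM, the lowest of the two numbers shown; the only single-place step measured so far is a 2.3-fold lower number from compound 2 to compound 3 (0.37 log units; beyond the scatter), and no single-place step joins compound 1 to either of them.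

Compound 4 `Cc1ccc(NC(=O)NC(=O)c2ccc(OCc3ccc(Cl)cc3Cl)cc2)cc1-c1nc2ccccc2[nH]1` differs from compound 3 in one place: 2,4-dichlorophenyl in place of 2-fluorophenyl on a saturated chain carbon bound to an oxygen on an aromatic ring. Within the data shown here, the one measured step that bears on this position, a 2.3-fold lower number from compound 2 to compound 3 (0.37 log units; beyond the scatter), shows that swapping the aryl group on the saturated chain carbon bound to the ring oxygen moves the number only modestly, so a step of similar size at most is expected for a 1.2-fold higher number from compound 3 to compound 4 (0.09 log units; within the scatter), with no firm direction. Compound 4 is therefore estimated at 5000 nM in this assay, within a range of 1500 nM to 20000 nM.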

Compound 4, half-maximal inhibitory concentration: 12200 nM
The estimate for compound 4 lay 2.4-fold (0.39 log units) below the measured number; the measured number falls inside the stated range.
By their numbers in this assay, from the lowest: compound 3; then compounds 2 and 4 (each within the scatter of the next). At a limit, above all of these: compound 1.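

In this assay the change to 2,4-dichlorophenyl gives a 3.0-fold higher number from compound 3 to compound 4 (0.47 log units; beyond the scatter), so this position responds to a second aryl swap and not only to the one seen earlier. Set against 3-(trifluoromethyl)phenyl, the same group gives a 1.3-fold higher number from compound 2 to compound 4 (0.10 log units; within the scatter), so these two cannot be told apart here, while 2-fluorophenyl is the one aryl group of the three whose steps to both others lie beyond the scatter. Nothing among the data shown bears on a cause for these steps.

As far as these compounds go, whether an amine or a carboxylic acid on this aryl ring, or a longer chain in place of the saturated chain carbon, would shift the number remains open. Among these compounds, compound 1, a limit of the assay at > 100000 nM, joins no other compound by a single-place step, so what separates it from the others stays unread.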